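A few compounds are considered here, and "the series" means these few. Any claim that something is new, unique, unknown or untested is made for them only; others in the source may bear on it.

Of the compounds shown here, three sharing one core have been tested in a functional assay on A549 cells (Homo sapiens) for cytotoxicity, read by MTT assay, with a stated time of 72 h; on this read-out lower numbers stand for stronger inhibition and higher numbers for weaker inhibition: compound 1 (`O=C(/C=C/c1ccc([N+](=O)[O-])cc1)Nc1cc2c(Nc3ccc(F)c(Cl)c3)ncnc2cc1O[C@H]1CCOC1`), compound 2 (`COc1cc(/C=C/C(=O)Nc2cc3c(Nc4ccc(F)c(Cl)c4)ncnc3cc2O[C@H]2CCOC2)cc(OC)c1OC`) and compound 3 (`COc1ccc(OC)c(/C=C/C(=O)Nc2cc3c(Nc4ccc(F)c(Cl)c4)ncnc3cc2O[C@H]2CCOC2)c1`). They differ only in the aromatic group on a double-bonded chain carbon bound to a double-bonded chain carbon. Compound 1 gives 12000 nM, compound 2 gives 4150 nM, and compound 3 gives 7300 nM. Compound 3 thus holds the middle place among the three numbers, although its gaps to both others lie within the scatter.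

For the measured compounds named here, the next candidate, compound 4 (`O=C(/C=C/c1cc(Br)c(O)c(Br)c1)Nc1cc2c(Nc3ccc(F)c(Cl)c3)ncnc2cc1O[C@H]1CCOC1`), keeps the core and exchanges only that group: 3,5-dibromo-4-hydroxyphenyl in place of 2,5-dimethoxyphenyl on a double-bonded chain carbon bound to a double-bonded chain carbon. Going by the values given here, no measured compound carries a 3,5-dibromo-4-hydroxyphenyl group, so the data offer no direct precedent. Among the compounds with values here, the best guide is how far exchanges at this place have moved the number so far. The largest gave a 2.9-fold lower number from compound 1 to compound 2 (0.46 log units; beyond the scatter), a modest change, while the others gave a 1.6-fold lower number from compound 1 to compound 3 (0.22 log units; within the scatter) and a 1.8-fold higher number from compound 2 to compound 3 (0.25 log units; within the scatter), both within the scatter. A step beyond the scatter is therefore not expected, and the data favour no clear direction. The expected change is a 1.2-fold lower number from compound 3 to compound 4 (0.09 log units; within the scatter). The estimated value for compound 4 is 6000 nM, with an expected range from 2000 nM to 15000 nM.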

Compound 4, half-maximal inhibitory concentration: 28800 nM
For compound 4 the middle estimate is 4.8-fold (0.68 log units) below the measured one; measured number above the stated range.
By their numbers in this assay, from the lowest: compounds 2, 3 and 1 (each within the scatter of the next, the first and the last beyond it); then compound 4.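

Set against every earlier group at this place on the double-bonded chain carbon, 3,5-dibromo-4-hydroxyphenyl goes the same way in this assay: the steps are a 3.9-fold higher number from compound 3 to compound 4 (0.60 log units; beyond the scatter) and a 6.9-fold higher number from compound 2 to compound 4 (0.84 log units; beyond the scatter) and a 2.4-fold higher number from compound 1 to compound 4 (0.38 log units; beyond the scatter), all beyond the scatter. For the compounds shown here, compound 4 therefore has the weakest result of the four, and the group is the first here to give a number clearly higher than that of compound 1, whose 4-nitrophenyl group had marked the high end of the series. The position thus tolerates exchange less freely than the three earlier compounds suggested, although the data shown give no explanation for this rise.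

This exchange brings in bromine and a hydroxy group together and removes both methoxy groups, so the compounds shown cannot say which of these parts goes with the higher number. A hydroxyphenyl group without bromine and a dibromophenyl group without the hydroxy would separate the two, while an aminophenyl or carboxyphenyl group at this place remains an open question.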